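The source may hold more compounds than are shown below. What is called first, only, known or untested is meant among the compounds shown, and "the series" means these compounds.

Measured compounds:
compound 1 `COC(=O)CNc1c(C(=O)NCc2ccc(F)cc2)nc(Br)c2cccnc12` — in a functional assay on MCF7 cells (Homo sapiens) for cytotoxicity, read by MTT assay, with a stated time of 72 h (a higher number here means a weaker inhibitor, a lower number a stronger inhibitor), compound 1 gives only a limit, > 10000 nM
compound 2 `O=C(NCc1ccc(F)cc1)c1nc(Br)c2cccnc2c1N1CCNCC1` — in this assay compound 2 gives 7000 nM
compound 3 `CNc1c(C(=O)NCc2ccc(F)cc2)nc(Br)c2cccnc12` — in this assay compound 3 gives "not determined" (no result reported)

Compound 3 stands nowhere on the numbers shown: no value was reported for it. Of the three entries, one is a limit rather than a number (the limit of > 10000 nM in this assay, at which 1 of the 3 values shown sits), and it belongs to compound 1.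

Compound 4 `Nc1cccc(Nc2c(C(=O)NCc3ccc(F)cc3)nc(Br)c3cccnc23)c1` differs from compound 3 in one place (3-aminophenyl in place of methyl on a nitrogen on an aromatic ring). Within the data shown here, the only measured step, an at least 1.4-fold lower number from compound 1 to compound 2 (0.15 log units; that floor lies within the scatter), also alters the substituent on that ring carbon, but replaces the whole amino group rather than the group on its nitrogen, and it lies within the scatter. It therefore gives no direction, and the step to compound 4 is expected to be no larger than the scatter around a weak value. Compound 4 is estimated at 6000 nM, between 1500 nM and 20000 nM.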

Compound 4, half-maximal inhibitory concentration: 8000 nM
Compound 4: middle estimate off by 1.3-fold (0.12 log units), on the low side; the range from low to high includes it.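

In this assay, a (3-aminophenyl)amino group on this aromatic carbon reads the same as piperazin-1-yl, with a 1.1-fold higher number from compound 2 to compound 4 (0.06 log units; within the scatter). The comparison with the (methoxycarbonyl)methyl group on the nitrogen also shows no change beyond the scatter, with an at least 1.2-fold lower number from compound 1 to compound 4 (0.09 log units; that floor lies within the scatter). Compound 1 gives only a limit, not a number, so the true size of that step stays unknown: the limit of > 10000 nM in this assay, at which 1 of the 4 values shown sits.

From the compounds shown here alone, what stays open is whether any group at this place can move the number beyond the scatter. A carboxylic acid or a longer alkyl chain on this nitrogen would be one way to test that.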